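This account rests on a few compounds, and the source may have more. Where it says the series, first, only, none or still open, it means among the compounds named here.

- compound 1 `OC[C@H]1OC(n2cnc3c(-c4ccoc4)ncnc32)[C@H](O)[C@@H]1O`: 3300 nM
- compound 2 `OC[C@H]1OC(n2cnc3c(-c4nccs4)ncnc32)[C@H](O)[C@@H]1O`: 6300 nM
- compound 3 `OC[C@H]1OC(n2cnc3c(-c4cc[nH]n4)ncnc32)[C@H](O)[C@@H]1O`: not yet measured

In a functional assay on HL-60 cells (Homo sapiens) for inhibition (a higher number here means a weaker inhibitor, a lower number a stronger inhibitor), compound 2 stands at 6300 nM and compound 1 stands at 3300 nM. Among the compounds with values here, these two numbers cannot be ranked, since the only measured step, a 1.9-fold higher number from compound 1 to compound 2 (0.28 log units; within the scatter), lies within the scatter. That step put 1,3-thiazol-2-yl in place of furan-3-yl on an aromatic carbon.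

Compound 3 has 1H-pyrazol-3-yl in place of 1,3-thiazol-2-yl on an aromatic carbon. Within the data shown here, one small step is thin evidence, and no measured compound carries a hydrogen-bond donor on this ring. Given a 1.9-fold higher number from compound 1 to compound 2 (0.28 log units; within the scatter), no step beyond the scatter is expected, though a wide range is kept in either direction. The expected step is a 1.3-fold lower number from compound 2 to compound 3 (0.10 log units; within the scatter). For compound 3 the estimated value is 5000 nM, within an expected range of 1200 nM to 22000 nM.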

Compound 3, half-maximal inhibitory concentration: 1170 nM
Compound 3: the middle estimate sits 4.3-fold (0.63 log units) above what was measured; the whole stated range lies above it.
By their numbers in this assay, from the lowest: compound 3; then compounds 1 and 2 (each within the scatter of the next).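

In this assay this position on the six-membered aromatic ring responds to the choice of five-membered ring: 1H-pyrazol-3-yl in place of 1,3-thiazol-2-yl gives a 5.4-fold lower number from compound 2 to compound 3 (0.73 log units; beyond the scatter) and in place of furan-3-yl gives a 2.8-fold lower number from compound 1 to compound 3 (0.45 log units; beyond the scatter), whereas the earlier change stayed within the scatter. The 1H-pyrazol-3-yl group has the same heavy-atom count as the 1,3-thiazol-2-yl group it replaces but carries a hydrogen-bond donor, so compound 3 is the strongest inhibitor of the three, although a single compound cannot tie that gain to the donor. No measured evidence accounts for the gain.

On these data alone, it remains open whether a 1-methyl-1H-pyrazol-3-yl group, which lacks the ring hydrogen, would hold this level. As far as these compounds go, how an imidazol-2-yl ring or a simple amine would read at this position also remains open.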